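Swapping a bromobenzyl for a benzimidazolylmethyl on a sulfonamide

This account rests on a few compounds, and the source may have more. Where it says the series, first, only, none or still open, it means among the compounds named here.

Compound 1 `COc1ccc(CN(c2cc(OC)c(OC)c(OC)c2)S(=O)(=O)c2ccc(C)cc2)cc1` gives 10100 nM in a functional assay on MCF7 cells (Homo sapiens) for inhibition, read by MTT assay, with a stated time of 48 h; on this read-out higher numbers stand for weaker inhibition and lower numbers for stronger inhibition.
Compound 2 `COc1ccc(CN(c2cc(OC)c(OC)c(OC)c2)S(=O)(=O)c2ccccc2)cc1` reaches only the limit of this assay, > 50000 nM.
Compound 3 `COc1cc(N(Cc2ccc(Br)cc2)S(=O)(=O)c2ccc(C)cc2)cc(OC)c1OC` gives 10900 nM.

Compound 3 and compound 1 therefore sit together, as a 1.1-fold higher number from compound 1 to compound 3 (0.03 log units; within the scatter) shows; the third value is a limit rather than a number, so compound 3 cannot be placed against compound 2. For the measured compounds named here, the only step beyond the scatter, an at least 4.9-fold higher number from compound 1 to compound 2 (0.69 log units; beyond the scatter), concerns a methyl on an aromatic carbon that compound 4 keeps unchanged. Compound 4 `COc1cc(N(Cc2nc3ccccc3[nH]2)S(=O)(=O)c2ccc(C)cc2)cc(OC)c1OC` differs from compound 3 at the group attached to the sulfonamide nitrogen through a saturated carbon: 1H-benzimidazol-2-yl in place of 4-bromophenyl on a saturated chain carbon bound to a sulfonamide nitrogen. Going by the values given here, the flat step between compound 1 and compound 3 exchanged only a substituent on that ring; here the whole 4-bromophenyl gives way to 1H-benzimidazol-2-yl, a change no measured step covers. A modest weakening is expected, a 1.5-fold higher number from compound 3 to compound 4 (0.17 log units; within the scatter), with wide uncertainty. Compound 4 is estimated at 16000 nM in this assay, between 4000 nM and 50000 nM.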

Compound 4, half-maximal inhibitory concentration: 5400 nM
Beside the measured number, compound 4's estimate is 3.0-fold (0.47 log units) above it, within the range that was stated.
By their numbers in this assay, from the lowest: compounds 4, 1 and 3 (each within the scatter of the next, the first and the last beyond it). At a limit, above all of these: compound 2.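

This place, on a saturated chain carbon bound to a sulfonamide nitrogen, tolerates more than a change of substituent on a phenyl ring: 1H-benzimidazol-2-yl, with its second ring and its hydrogen-bond donor, gives a 2.0-fold lower number from compound 3 to compound 4 (0.31 log units; beyond the scatter) in this assay. The gain is small and holds only against 4-bromophenyl, since a 1.9-fold lower number from compound 1 to compound 4 (0.27 log units; within the scatter) leaves compound 4 and compound 1 within the scatter of each other. No measurement shown here accounts for the step from 4-bromophenyl to 1H-benzimidazol-2-yl.

From the compounds shown here alone, what an amine, a carboxylic acid or a pyridine ring would do at this place remains open. So does whether hydrogen in place of the methyl on the aromatic carbon would cost as much with 1H-benzimidazol-2-yl present as it does with 4-methoxyphenyl.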